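The source may report more compounds than this note shows. Statements on the series, on what has been measured and on what is new or still open speak of the compounds shown alone.

In a functional assay on HeLa cells (Homo sapiens) for antiproliferative activity, read by CCK-8 assay, with a stated time of 72 h (a lower number here means a stronger inhibitor, a higher number a weaker inhibitor), two compounds on a shared core have been measured so far. Compound 1 (`Cc1cc(Nc2cc(N3CCN(C)CC3)nc(Nc3ccc(S(N)(=O)=O)cc3)n2)n[nH]1`) gives 3060 nM as its value, and compound 2 (`Cc1cc(Nc2cc(N3CCN(C)CC3)nc(Nc3cccc(Cl)c3)n2)n[nH]1`) gives 425 nM as its value, the lower of the two numbers. Compound 3 (`Cc1cc(Nc2cc(N3CCN(C)CC3)nc(Nc3ccc(C#N)cc3)n2)n[nH]1`) carries 4-cyanophenyl in place of 3-chlorophenyl on a nitrogen on an aromatic ring. For the measured compounds named here, only one measured step bears on this change: a 7.2-fold lower number from compound 1 to compound 2 (0.86 log units; beyond the scatter) came with 3-chlorophenyl replacing 4-sulfamoylphenyl at that same place. Compound 3 gives up 3-chlorophenyl too, but 4-cyanophenyl is a different group from 4-sulfamoylphenyl, so only part of that step is expected to be reversed. The expected shift is a 2.1-fold higher number from compound 2 to compound 3 (0.33 log units; beyond the scatter) in this assay and would be a modest weakening. For compound 3 the estimated value is 900 nM with an expected range from 280 nM to 2900 nM in this measurement.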

Compound 3, half-maximal inhibitory concentration: 331 nM
For compound 3 the middle estimate is 2.7-fold (0.43 log units) above the measured one; the measured number falls inside the stated range.
By their numbers in this assay, from the lowest: compounds 3 and 2 (each within the scatter of the next); then compound 1.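

In this assay, the change on this nitrogen gives a 1.3-fold lower number from compound 2 to compound 3 (0.11 log units; within the scatter), so 3-chlorophenyl and 4-cyanophenyl cannot be told apart here, although they carry different substituents at different ring positions. The other new comparison, with the ring position held the same, gives a 9.2-fold lower number from compound 1 to compound 3 (0.97 log units; beyond the scatter), so among these three compounds the high number of compound 1 goes with its sulfamoyl group and not simply with having a substituent at the 4-position. No measurement shown here explains either step.

As far as these compounds go, whether 3-cyanophenyl or 4-chlorophenyl would fit the same picture remains open, and these two groups would separate the effect of the substituent from that of its ring position. It is also unknown how an amine or a carboxylic acid on this ring would behave.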